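Nitro for methyl on the sulfonyl aryl of compound 2

A few compounds are considered here, and "the series" means these few. Any claim that something is new, unique, unknown or untested is made for them only; others in the source may bear on it.

Measured compounds:
compound 1 `O=C(C(c1ccccc1)c1ccccc1)N1CCN(CCCn2c(=O)[nH]c3ccccc32)CC1` gives 7800 nM
compound 2 `Cc1ccc(S(=O)(=O)N2CCN(CCCn3c(=O)[nH]c4ccccc43)CC2)cc1` gives > 10000 nM

In an assay on RPMI-8226 cells for antagonist activity at P2X purinoceptor 7 (Homo sapiens), read by calcium flux (a lower number here means a stronger inhibitor, a higher number a weaker inhibitor), compound 1 gives 7800 nM. For compound 2 the result is only a limit of the assay, > 10000 nM, so compound 2 stands at the limit of > 10000 nM in this assay, at which 1 of the 2 values shown sits, and no number is known for it. Compound 3 `O=c1[nH]c2ccccc2n1CCCN1CCN(S(=O)(=O)c2ccc([N+](=O)[O-])cc2)CC1` differs from compound 2 by nitro in place of methyl on an aromatic carbon. For the measured compounds named here, no measured pair shows such a change, so there is no step to lean on. Compound 3 is expected to remain weak in this assay, with a step that the limit leaves unreadable from compound 2 to compound 3 that is not expected to leave the scatter in either direction, and a fair chance that compound 3 again returns only a limit. The estimate for compound 3 is 12000 nM, between 3000 nM and 50000 nM.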

Compound 3, half-maximal inhibitory concentration: > 10000 nM
Compound 3: a limit, no number (the forecaster's own chance of this, stated with the estimate: 65%); the middle value lies beyond the limit too.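

Compound 2 and compound 3 each return only a limit in this assay, so no step can be read between them: the limit of > 10000 nM in this assay, at which 2 of the 3 values shown sit. The compounds shown leave open whether nitro in place of methyl on the aromatic carbon changes the inhibition at all, and in which direction.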